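The source may hold more compounds than are shown below. What is called first, only, known or untested is meant among the compounds shown, and "the series" means these compounds.

Measured so far:
Compound 1 `COc1ccc(/C=C\C(=O)O)c(OCc2cn(-c3ccccc3)nn2)c1CC=C(C)C`, which in a functional assay on HCT-116 cells (Homo sapiens) for cytotoxicity, read by MTT assay, with a stated time of 24 h (a lower number here means a stronger inhibitor, a higher number a weaker inhibitor), gives 26000 nM.
Compound 2 `COc1ccc(/C=C\C(=O)O)c(OCc2cn(-c3ccccc3I)nn2)c1CC=C(C)C`, which in this assay gives 23100 nM.

On these two numbers compound 2 stands beside compound 1: the step of a 1.1-fold lower number from compound 1 to compound 2 (0.05 log units; within the scatter) lies within the scatter, so neither compound is set apart from the other. Compound 3 `COc1ccc(/C=C\C(=O)O)c(OCc2cn(-c3nc4ccccc4s3)nn2)c1CC=C(C)C` differs from compound 2 by 1,3-benzothiazol-2-yl in place of 2-iodophenyl on an aromatic nitrogen. Within the data shown here, the only measured step, a 1.1-fold lower number from compound 1 to compound 2 (0.05 log units; within the scatter), concerns iodo in place of hydrogen on an aromatic carbon of the group that now leaves, and it bears only loosely on the exchange of that whole group for 1,3-benzothiazol-2-yl. Among the measured compounds shown here, nothing among the measured compounds points to a shift beyond the scatter in this assay, so compound 3 is expected to give a number close to that of compound 2. The expected step is a 1.1-fold lower number from compound 2 to compound 3 (0.02 log units; within the scatter). For compound 3 the estimate is 22000 nM, with a range from 8000 nM to 60000 nM.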

Compound 3, half-maximal inhibitory concentration: 16400 nM
Estimate against measurement, compound 3: 1.3-fold (0.13 log units) above; the measured number falls inside the stated range.
By their numbers in this assay, from the lowest: compounds 3, 2 and 1 (each within the scatter of the next).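

In this assay, 1,3-benzothiazol-2-yl in place of 2-iodophenyl on an aromatic nitrogen gives one step (a 1.4-fold lower number from compound 2 to compound 3 (0.15 log units; within the scatter)), and the same group in place of phenyl gives another (a 1.6-fold lower number from compound 1 to compound 3 (0.20 log units; within the scatter)). The earlier pair covered only an iodo on the phenyl, whereas these steps show that a group with a second aromatic ring and 2 hydrogen-bond acceptors can stand at this position without a step beyond the scatter. No measurement available here accounts for these numbers.

The compounds shown leave open whether any group on this nitrogen can move the number beyond the scatter. An amine on the phenyl, or a saturated alkyl chain in place of the aromatic group, would test this, and the outcome cannot be told from these three compounds.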